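This account rests on a few compounds, and the source may have more. Where it says the series, first, only, none or still open, it means among the compounds named here.

Compounds measured in a functional assay on ileum (Cavia porcellus) with cysteinyl leukotriene receptor (Homo sapiens) as the target; on this read-out higher numbers stand for higher potency (the scale is a negative logarithm) and lower numbers for lower potency:
- compound 1 `CCCc1c(COc2ccc(C(=O)Cc3nnn[nH]3)cc2)ccc(C(C)=O)c1O` gives 7.71
- compound 2 `CCCc1c(COc2ccc(C(=O)CCc3nnn[nH]3)cc2)ccc(C(C)=O)c1O` gives 7.09
- compound 3 `CCCc1c(COc2ccc(C(=O)C(C)(C)Cc3nnn[nH]3)cc2)ccc(C(C)=O)c1O` gives 6.93

Among these three numbers compound 2 stands second highest. Its nearest neighbour is compound 3, and the step of a number 0.16 log units lower from compound 2 to compound 3 (within the scatter) lies within the scatter, so the two cannot be ordered. Its furthest is compound 1, and the step of a number 0.62 log units lower from compound 1 to compound 2 (beyond the scatter) is beyond the scatter.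

Compound 4 `CCCc1c(COc2ccc(C(=O)CCCC(=O)O)cc2)ccc(C(C)=O)c1O` differs from compound 2 in one place: carboxymethyl in place of 1H-tetrazol-5-yl on a saturated chain carbon, two bonds along the chain from a carbonyl carbon. Among the compounds with values here, none of the measured steps exchanges the 1H-tetrazol-5-yl for a carboxymethyl; the steps of a number 0.62 log units lower from compound 1 to compound 2 (beyond the scatter) and a number 0.78 log units lower from compound 1 to compound 3 (beyond the scatter) concern only the saturated chain that carries the ring, and the step of a number 0.16 log units lower from compound 2 to compound 3 (within the scatter) concerns branching of that chain. Within the data shown here, there is therefore no direct precedent for this change within the set, and the expectation rests on the group exchange itself, carried over a chain that was already the longer one in compound 2. A modest lowering is expected, with a wide range that also admits no step beyond the scatter: for compound 4 the step is estimated as a number 0.49 log units lower from compound 2 to compound 4 (beyond the scatter). In this assay compound 4 is thus expected to give 6.6, within a range from 5.9 to 7.3.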

Compound 4, negative logarithm of the antagonist equilibrium constant: 6.81
Compound 4: the middle estimate sits 0.21 log units below what was measured; the range from low to high includes it.
By their numbers in this assay, from the lowest: compounds 4, 3 and 2 (each within the scatter of the next); then compound 1.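

In this assay, carboxymethyl in place of 1H-tetrazol-5-yl on a saturated chain carbon, two bonds along the chain from a carbonyl carbon, leaves a number 0.28 log units lower from compound 2 to compound 4 (within the scatter), so at this position the five-membered ring can give way to an open group without a change that can be told from the scatter. The other steps place compound 4 with compound 3, as a number 0.12 log units lower from compound 3 to compound 4 (within the scatter) also cannot be ordered. In contrast, the step of a number 0.90 log units lower from compound 1 to compound 4 (beyond the scatter) sets those two apart. Compound 1 stands apart in the same way from compound 2 and from compound 3. Nothing available explains why the exchange is so well tolerated here.

The compounds shown leave open whether the same exchange would be tolerated on the shorter chain of compound 1, with carboxymethyl on the saturated chain carbon bound to a carbonyl carbon, since the only carboxylic acid among them sits on the longer chain. They also leave open how a carboxylic acid would fare on the branched chain of compound 3, with its two methyl groups, or on a chain longer than the 3-carboxypropyl of compound 4.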